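Compound 4: hydrogen in place of 2-cyanoethenyl

This account rests on a few compounds, and the source may have more. Where it says the series, first, only, none or still open, it means among the compounds named here.

Compound 1 `C=C[C@@](C)(/C=C/c1ccc(O)cc1)CC/C=C/C(=O)OCC`: > 36600 nM (a limit)
Compound 2 `C=C[C@@](C)(/C=C/c1ccc(O)c(/C=C/C(=O)NCc2ccc(C(F)(F)F)cc2)c1)CCC=C(C)C`: > 36600 nM (a limit)
Compound 3 `COc1ccc(/C=C/[C@@](C)(/C=C/c2ccc(O)c(/C=C/C#N)c2)CCC=C(C)C)cc1`: 4540 nM

Among the measured compounds shown here, in a functional assay on SEM cells (Homo sapiens) for cytotoxicity, with a stated time of 72 h (on this read-out lower numbers stand for an effect already at smaller amounts and higher numbers for an effect only at larger amounts of compound), compound 3 gives 4540 nM as the only actual number. Compound 1 and compound 2 give no number, only a limit (the limit of > 36600 nM in this assay, at which 2 of the 3 values shown sit). Compound 4 (`COc1ccc(/C=C/[C@@](C)(/C=C/c2ccc(O)cc2)CCC=C(C)C)cc1`) is still to be measured and carries hydrogen in place of 2-cyanoethenyl on an aromatic carbon of compound 3 (hydrogen in place of 2-cyanoethenyl on an aromatic carbon).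

For the measured compounds named here, no measured pair isolates this change, so the expectation is rough. Compound 1 also lacks the 2-cyanoethenyl group, and its > 36600 nM is a limit. Compound 2 lacks it too, and its > 36600 nM is a limit. Both also differ from compound 3 elsewhere. A step towards higher numbers, beyond the usual scatter, is expected in this assay, and a reading at the limit would not surprise. The expected change is a 3.5-fold higher number from compound 3 to compound 4 (0.55 log units; beyond the scatter) on this estimate. For compound 4 the estimated value is 16000 nM within a range of 5000 nM to 36600 nM as expected bounds.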

Compound 4, half-maximal effective concentration: > 36600 nM
Compound 4: a limit, no number; the forecaster's own chance of this, stated with the estimate: 45%; middle value at least 2.2-fold (0.35 log units) away from the limit.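

In this assay, hydrogen in place of 2-cyanoethenyl on the aromatic carbon ortho to the hydroxy group gives an at least 8.0-fold higher number from compound 3 to compound 4 (0.90 log units; beyond the scatter). Among the compounds shown here, this is the only pair that differs in one place, so it ties the sole measured number directly to the 2-cyanoethenyl group, which compound 1 and compound 2 could not do, as both differ from compound 3 in other places as well. Compound 4 gives > 36600 nM, which is a limit, so the step sets only a lower bound on the size of the change: the limit of > 36600 nM in this assay, at which 3 of the 4 values shown sit.

From the compounds shown here alone, whether the nitrile or the double bond of the 2-cyanoethenyl group matters remains open; a 2-cyanoethyl chain, a nitrile or a carboxylic acid on this carbon would separate them. Going by these compounds, it also remains open whether the same change holds on a core without the methoxy group.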